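The compounds below may be only part of what the source reports. "The series", "measured", "known", "first", "only" and "open" are said of these compounds alone.

Measured compounds:
Compound 1 `Clc1cccc(-n2ncnc2Nc2ccccc2)c1Cl`: 363 nM
Compound 2 `Clc1cccc(-n2ncnc2NCc2ccccc2)c1Cl`: 47.9 nM
Compound 3 `COc1cccc(CNc2ncnn2-c2cccc(Cl)c2Cl)c1`: 288 nM

These three compounds were tested in a functional assay for antagonist activity at P2X purinoceptor 7 (Homo sapiens), read by FLIPR and calcium flux; a lower number here means a stronger inhibitor, a higher number a weaker inhibitor. Compound 2 gives the lowest number of the three: compound 1, which carries a phenyl group instead of the benzyl group on the ring nitrogen, shows a 7.6-fold lower number from compound 1 to compound 2 (0.88 log units; beyond the scatter), and compound 3, which carries a methoxy group on the benzyl ring, shows a 6.0-fold higher number from compound 2 to compound 3 (0.78 log units; beyond the scatter).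

Compound 4 `CSc1ccccc1CNc1ncnn1-c1cccc(Cl)c1Cl` has not been measured. It differs from compound 2 in one place: methylsulfanyl in place of hydrogen on an aromatic carbon. For the measured compounds named here, the step that bears most directly on this is the one from compound 2 to compound 3, where a small group added to the same benzyl ring gave a modest weakening; the step from compound 1 to compound 2 shows how much the group on the ring nitrogen matters but involves a different kind of change. Going by the values given here, only one added-group example exists, and it sits at a different position, so the expectation is uncertain. A weakening of similar, perhaps somewhat smaller, size is expected: compound 4 is estimated at 130 nM, a step of a 2.7-fold higher number from compound 2 to compound 4 (0.43 log units; beyond the scatter), with a range from 45 nM to 400 nM.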

Compound 4, half-maximal inhibitory concentration: 49 nM
Beside the measured number, compound 4's estimate is 2.7-fold (0.42 log units) above it; the measured number falls inside the stated range.
By their numbers in this assay, from the lowest: compounds 2 and 4 (each within the scatter of the next); then compounds 3 and 1 (each within the scatter of the next).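

In this assay, methylsulfanyl on an aromatic carbon, ortho to a large group, gives a number level with that of the unsubstituted benzyl compound: a 1.0-fold higher number from compound 2 to compound 4 (0.01 log units; within the scatter). So an added group on this ring need not weaken the compound, even though the methoxy group of compound 3, on a different ring carbon, gave a 6.0-fold higher number from compound 2 to compound 3 (0.78 log units; beyond the scatter). The data shown offer no measurement that explains this difference between the two added groups.

The two added groups differ both in their atoms and in where they sit, so these compounds cannot separate one change from the other. Going by these compounds, it also remains open whether an amine, a carboxylic acid or a single fluorine at this same ring carbon would match compound 2, and how methylsulfanyl would fare on another ring carbon.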